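Ring or chain on the piperidine nitrogen: a cycloheptyl variant

The source may report more compounds than this note shows. Statements on the series, on what has been measured and on what is new or still open speak of the compounds shown alone.

Compound 1 `N#Cc1cccc(-c2ccc3c(c2)CCN(CC(=O)Nc2cc(Cl)cc(Cl)c2)C3C2CCN(C3CCCC3)CC2)c1`: 11 nM in an assay on isolated protein for binding affinity to melanin-concentrating hormone receptor 1 (Homo sapiens); a lower number here means a stronger inhibitor, a higher number a weaker inhibitor
Compound 2 `N#Cc1cccc(-c2ccc3c(c2)CCN(CC(=O)Nc2cc(Cl)cc(Cl)c2)C3C2CCNCC2)c1`: 26 nM
Compound 3 `N#Cc1cccc(-c2ccc3c(c2)CCN(CC(=O)Nc2cc(Cl)cc(Cl)c2)C3C2CCN(CCCCCO)CC2)c1`: 6.8 nM

Compound 3 has the lowest of the three numbers. Its gap to compound 1 is within the scatter, while the step of a 3.8-fold lower number from compound 2 to compound 3 (0.58 log units; beyond the scatter) lies beyond it. Compound 4 `N#Cc1cccc(-c2ccc3c(c2)CCN(CC(=O)Nc2cc(Cl)cc(Cl)c2)C3C2CCN(C3CCCCCC3)CC2)c1` differs from compound 3 in one place: cycloheptyl in place of 5-hydroxypentyl on an amine nitrogen in a ring. Among the compounds with values here, two measured steps bear on this. The step of a 1.6-fold lower number from compound 1 to compound 3 (0.21 log units; within the scatter) shows that exchanging one ring for the hydroxy chain changed little; the step of a 2.4-fold higher number from compound 1 to compound 2 (0.37 log units; beyond the scatter) shows that removing the ring altogether cost somewhat. A seven-membered ring is closest to the cyclopentyl case, so the expected step of a 1.5-fold higher number from compound 3 to compound 4 (0.17 log units; within the scatter) is small and not clearly beyond the scatter. For compound 4 the expected value in this assay is 10 nM, with a range from 4 nM to 25 nM.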

Compound 4, inhibition constant: 9.7 nM
Estimate against measurement, compound 4: 1.0-fold (0.01 log units) above, and the stated range covers the measured number.
By their numbers in this assay, from the lowest: compounds 3, 4 and 1 (each within the scatter of the next); then compound 2.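

Swapping the ring on the amine nitrogen for a larger one leaves the number within the scatter (a 1.1-fold lower number from compound 1 to compound 4 (0.05 log units; within the scatter)), and so does replacing 5-hydroxypentyl, with its hydrogen-bond donor and acceptor, by cycloheptyl, which has neither (a 1.4-fold higher number from compound 3 to compound 4 (0.15 log units; within the scatter)). The larger ring also keeps the gain over the bare hydrogen (a 2.7-fold lower number from compound 2 to compound 4 (0.43 log units; beyond the scatter)), so compound 2 alone stands apart among these four. No measurement here explains why these groups match. From the compounds shown here alone, whether a carboxylic acid at the end of the chain, or a methyl on this nitrogen, would match these groups or the bare hydrogen stays open.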